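This account rests on a few compounds, and the source may have more. Where it says the series, first, only, none or still open, it means among the compounds named here.

The measured compounds and their values:

Compound 1, `CCOC(=O)CSc1nnc(C)n1N1C(=O)c2ccccc2C1=O`, gives in a functional assay on HepG2 cells (Homo sapiens) for cytotoxicity, read by MTT assay, with a stated time of 48 h (a lower number here means a stronger inhibitor, a higher number a weaker inhibitor), a value that is only a limit, > 200000 nM.
Compound 2, `Cc1nnc(SCC(=O)c2ccc(Cl)cc2)n1N1C(=O)c2ccccc2C1=O`, gives in this assay a value that is only a limit, > 200000 nM.
Compound 3, `Cc1nnc(SCC(=O)c2ccccc2)n1N1C(=O)c2ccccc2C1=O`, gives in this assay a value that is only a limit, > 200000 nM.

Compound 3 therefore sits at the limit of > 200000 nM in this assay, at which 3 of the 3 values shown sit. None of the three is distinguished from the others by a readable number. The step from compound 1 to compound 2 is a step that the two limits leave unreadable from compound 1 to compound 2, the step from compound 1 to compound 3 is a step that the two limits leave unreadable from compound 1 to compound 3, and the step from compound 2 to compound 3 is a step that the two limits leave unreadable from compound 2 to compound 3. Within the data shown here, no measured step gives a size that can be carried over.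

Compound 4, `C#CCSc1nnc(C)n1N1C(=O)c2ccccc2C1=O`, has not yet been measured in this assay. It differs from compound 3 by ethynyl in place of benzoyl on a saturated chain carbon bound to a sulfur. Since every measured step bearing on the sulfur-bound chain is unreadable, the step from compound 3 to compound 4 is expected to be a number no higher from compound 3 to compound 4 (the limit leaves the size open), with the result most likely again a limit. Compound 4 is estimated at 200000 nM, with a range from 60000 nM to 600000 nM.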

Compound 4, half-maximal inhibitory concentration: > 200000 nM
Compound 4: a limit, no number (the forecaster's own chance of this, stated with the estimate: 75%); the middle value lies on the limit itself.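

In this assay compound 4 gives > 200000 nM, which is only a limit. Among these compounds, no step to compound 4 from compound 1, compound 2 or compound 3 can be read, and all four compounds remain at one limit: the limit of > 200000 nM in this assay, at which 4 of the 4 values shown sit. The compounds shown leave open whether any group on the saturated chain carbon bound to a sulfur changes the read-out in this assay at all.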